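Cytotoxicity notes: nitrile for trifluoromethyl on two cores

The compounds below may be only part of what the source reports. "The series", "measured", "known", "first", "only" and "open" are said of these compounds alone.

Measured compounds:
- compound 1, `C/C1=C/C2=C[C@H](C)C[C@@]23O[C@]2(CC(C)(C)C[C@@H]2[C@@]1(O)C(F)(F)F)[C@@H](C)C3=O`: 26000 nM
- compound 2, `CC1=C2CC(C)(C)/C=C/C(=O)/C(C)=C\C3=C[C@H](C)C[C@]3(O2)[C@@]1(O)C(F)(F)F`: 26000 nM
- compound 3, `CC1=C2CC(C)(C)/C=C/C(=O)/C(C)=C\C3=C[C@H](C)C[C@]3(O2)[C@@]1(O)C#N`: 21200 nM

All three numbers come from an ADME assay on Raji cells (Homo sapiens) for cytotoxicity, read by CellTiter-Glo, with a stated time of 72 h; a higher number here means that more compound is needed for the effect, a lower number that less compound is needed. In this assay compound 1 gives 26000 nM, level with compound 2 at the digits given; these two together stand highest of the three numbers, and compound 3 differs from them only within the scatter. The difference between the core of compound 1 and the core of compound 2 is not broken down here.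

Within the data shown here, the one measured step is a 1.2-fold lower number from compound 2 to compound 3 (0.09 log units; within the scatter). Its structural content is cyano in place of trifluoromethyl on a saturated ring carbon.

The unmeasured compound is compound 4, `C/C1=C/C2=C[C@H](C)C[C@@]23O[C@]2(CC(C)(C)C[C@@H]2[C@@]1(O)C#N)[C@@H](C)C3=O`. It relates to compound 1 as compound 3 relates to compound 2: cyano in place of trifluoromethyl on a saturated ring carbon. The two places are not the same word for word: in compound 2 the saturated ring carbon sits on a five-membered non-aromatic ring with 1 oxygen, part of a fused or bridged system of three rings, whereas in compound 1 it sits on an eight-membered non-aromatic ring with 1 oxygen, part of a fused or bridged system of four rings. So this is the same kind of change on a different core, not the same change.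

In this assay the step from compound 1 to compound 4 is expected to be small, a 1.2-fold lower number from compound 1 to compound 4 (0.07 log units; within the scatter), resting on the earlier step, which was within the scatter, a 1.2-fold lower number from compound 2 to compound 3 (0.09 log units; within the scatter). For compound 4 the estimate in this assay is 22000 nM, with a range of 11000 nM to 44000 nM expected.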

Compound 4, half-maximal effective concentration: 26000 nM
Compound 4: middle estimate off by 1.2-fold (0.07 log units), on the low side, within the range that was stated.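

In this assay, cyano in place of trifluoromethyl on a saturated ring carbon gives no change at the digits printed from compound 1 to compound 4 (within the scatter), so on the core of compound 1 the exchange leaves no mark that can be told from the scatter. Set beside the earlier step, the exchange reads alike on the two cores: the same change on two cores in this assay, a 1.2-fold lower number (0.09 log units; within the scatter) from compound 2 to compound 3 and no change at the digits printed (within the scatter) from compound 1 to compound 4, 1.2-fold (0.09 log units) apart, within the scatter of two such steps. This shows that, for these two matched pairs and in this one cell read-out, trifluoromethyl and cyano could not be told apart at this carbon on either core, but it does not show that the exchange would read the same way on a third core or in any other assay, and two pairs are too few to make a rule for the series.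

The compounds shown leave open whether a different group on this saturated ring carbon, such as an amine, a carboxylic acid or a longer chain, would move the number in this assay beyond the scatter. Among these compounds, they also leave open which structural features of the two cores, if any, bear on the number, as no step here isolates one part of a core from the rest.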